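A few compounds are considered here, and "the series" means these few. Any claim that something is new, unique, unknown or untested is made for them only; others in the source may bear on it.

Three compounds built on one shared core differ only in what sits on a saturated chain carbon bound to an oxygen on an aromatic ring. Compound 1 `C=CCOc1cccc(/C=N/n2c(-c3ccccc3)nc3ccccc3c2=O)c1` carries a vinyl there; in a functional assay on the whole organism (strain albino CF-1) with Mus musculus as the target, in the maximal electroshock model, with a stated time of 4 h (a higher number here means that more compound is needed for the effect, a lower number that less compound is needed), compound 1 gives 300 mg/kg. Compound 2 `CCCCOc1cccc(/C=N/n2c(-c3ccccc3)nc3ccccc3c2=O)c1` carries a propyl there, and in this assay compound 2 gives 100 mg/kg. Compound 3 `COc1cccc(/C=N/n2c(-c3ccccc3)nc3ccccc3c2=O)c1` carries a hydrogen there, and in this assay compound 3 gives 100 mg/kg. So compound 3 stands level with compound 2, the two together holding the lowest numbers of the three, while compound 1 sits apart: a 3.0-fold lower number from compound 1 to compound 3 (0.48 log units; beyond the scatter) and a 3.0-fold lower number from compound 1 to compound 2 (0.48 log units; beyond the scatter), whereas no change at the digits printed from compound 2 to compound 3 (within the scatter).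

Compound 4 `CC(C)Oc1cccc(/C=N/n2c(-c3ccccc3)nc3ccccc3c2=O)c1` has not yet been measured. It differs from compound 3 by isopropyl in place of methyl on an oxygen on an aromatic ring. Going by the values given here, the step that bears most directly on this is the one that exchanges two saturated groups on that carbon: no change at the digits printed from compound 2 to compound 3 (within the scatter). The vinyl-bearing compound 1 is the only one that stands out, as a 3.0-fold lower number from compound 1 to compound 2 (0.48 log units; beyond the scatter) and a 3.0-fold lower number from compound 1 to compound 3 (0.48 log units; beyond the scatter) show. Since isopropyl is another saturated group, compound 4 is expected to show no change at the digits printed from compound 3 to compound 4 (within the scatter), nothing beyond the scatter. Compound 4 is therefore estimated at 100 mg/kg, with a range from 50 mg/kg to 300 mg/kg.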

Compound 4, minimum effective dose: 300 mg/kg
Beside the measured number, compound 4's estimate is 3.0-fold (0.48 log units) below it, within the range that was stated.
By their numbers in this assay, from the lowest: compounds 2 and 3 (each within the scatter of the next); then compounds 1 and 4 (each within the scatter of the next).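

Saturated groups on this oxygen are not interchangeable in this assay. Isopropyl in place of methyl gives a 3.0-fold higher number from compound 3 to compound 4 (0.48 log units; beyond the scatter) and isopropyl in place of butyl gives a 3.0-fold higher number from compound 2 to compound 4 (0.48 log units; beyond the scatter) as well, so the flat step between the methyl and butyl compounds does not hold for every saturated group, and the size of the group alone does not order these results, since isopropyl stands between methyl and butyl by heavy atoms yet goes against both. The allyl compound also no longer stands alone, as isopropyl in place of allyl gives no change at the digits printed from compound 1 to compound 4 (within the scatter) and so puts the isopropoxy and allyl ethers together, apart from the methoxy and butoxy ethers, and nothing available explains this split.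

Still open, on these data alone, is where an unbranched propyl on this oxygen would fall, which would help separate the effect of branching from that of chain length. Also open, as far as these compounds go, is whether a longer chain such as hexyl, a cyclopropylmethyl group or a chain ending in an amine would sit with the methoxy and butoxy ethers or with the other two.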